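Three Hydroxyphenyl Isomers on a Shared Core

The source may hold more compounds than are shown below. What is called first, only, known or untested is meant among the compounds shown, and "the series" means these compounds.

Compound 2 `Oc1ccccc1-c1cc(-c2ccccc2O)nc(-c2ccccc2O)c1` is tested in an ADME assay on HEK293 cells (Homo sapiens) for cytotoxicity, read by CCK-8 assay, with a stated time of 4 days (a higher number here means a weaker inhibitor, a lower number a stronger inhibitor), where compound 2 gives 140 nM. Among the two numbers measured so far that is the higher one; its nearest neighbour is compound 1 `Oc1cccc(-c2cc(-c3ccccc3O)nc(-c3ccccc3O)c2)c1`, which in this assay gives 80 nM. The step of a 1.8-fold higher number from compound 1 to compound 2 (0.24 log units; within the scatter) replaces 3-hydroxyphenyl by 2-hydroxyphenyl and stays within the scatter, so the two isomers cannot be told apart on these data.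

Compound 3 `Oc1ccc(-c2cc(-c3ccccc3O)nc(-c3ccccc3O)c2)cc1` differs from compound 2 by the change (4-hydroxyphenyl in place of 2-hydroxyphenyl on an aromatic carbon). Among the measured compounds shown here, no measured step covers a 4-hydroxyphenyl group, so the only guide is the step from compound 1 to compound 2, which showed that moving the hydroxyl around the ring left this assay essentially unchanged. Compound 3 is therefore expected to sit close to both measured compounds, with a step of a 1.3-fold lower number from compound 2 to compound 3 (0.10 log units; within the scatter) that falls within the scatter and has no clear direction. The estimate for compound 3 in this assay is 110 nM, with a range from 40 nM to 300 nM.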

Compound 3, half-maximal inhibitory concentration: > 50000 nM
Compound 3: a limit, no number; the forecaster's own chance of this, stated with the estimate: 3%; at least 450-fold (2.65 log units) between middle value and limit.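

Compound 3 stands at a limit of the assay, not at a number, in this assay: the limit of > 50000 nM in this assay, at which 1 of the 3 values shown sits. At this place, on the aromatic carbon opposite the ring nitrogen, the position of the hydroxyl on the phenyl ring turns out to matter: 4-hydroxyphenyl in place of 2-hydroxyphenyl gives an at least 350-fold higher number from compound 2 to compound 3 (2.55 log units; beyond the scatter), and 4-hydroxyphenyl in place of 3-hydroxyphenyl gives an at least 620-fold higher number from compound 1 to compound 3 (2.79 log units; beyond the scatter). The earlier step, a 1.8-fold higher number from compound 1 to compound 2 (0.24 log units; within the scatter), gave no hint of this, so the three isomers, alike in atoms and in their counts of hydrogen-bond donors and acceptors, do not behave as one group, and 4-hydroxyphenyl alone separates from the other two.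

The compounds shown leave open whether the hydroxyl of 4-hydroxyphenyl is itself what matters, since a plain phenyl, a 4-methoxyphenyl or a 4-aminophenyl at this place could fall with compound 3 or with compound 1 and compound 2. On these data alone, they also leave open how far the true value of compound 3 lies past its limit, so the full size of both large steps remains unknown.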